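Adding a Bromine to the Plain Phenyl Ring

The source may report more compounds than this note shows. Statements on the series, on what has been measured and on what is new or still open speak of the compounds shown alone.

Compound 1 `c1ccc(-c2nnc(-c3cn4ccccc4n3)o2)cc1` is the simplest member of this small set: an unsubstituted phenyl ring attached to the shared core. For the measured compounds named here, in a functional assay on PC-3 cells (Homo sapiens) for antiproliferative activity, read by MTT assay, with a stated time of 48 h (a lower number here means a stronger inhibitor, a higher number a weaker inhibitor), compound 1 gives 22200 nM, the highest number of the two measured so far. Going by the values given here, its only measured companion is compound 2 `COc1cc(-c2nnc(-c3cn4ccccc4n3)o2)cc(OC)c1OC`, which carries three methoxy groups on that phenyl ring; in this assay compound 2 gives 3500 nM. Among the compounds with values here, the gap between the two lies beyond the scatter, so compound 1 stands as the weaker of the pair, though with only two numbers no general rule can be drawn from this.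

Compound 3 `Brc1ccc(-c2nnc(-c3cn4ccccc4n3)o2)cc1` differs from compound 1 in a single place: bromo in place of hydrogen on an aromatic carbon. Within the data shown here, no measured pair shows this particular change, so its effect here is unknown. A modest drop in the number is expected, within or only just beyond the scatter, so the step is estimated as a 1.9-fold lower number from compound 1 to compound 3 (0.27 log units; within the scatter). Compound 3 is therefore expected to come in at about 12000 nM, with a plausible range from 4000 nM to 35000 nM.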

Compound 3, half-maximal inhibitory concentration: > 50000 nM
Compound 3: only a limit was reported; the forecaster's own chance of this, stated with the estimate: 10%; at least 4.1-fold (0.61 log units) between middle value and limit.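

The change from phenyl to 4-bromophenyl gives an at least 2.2-fold higher number from compound 1 to compound 3 (0.35 log units; beyond the scatter) in this assay, so here a single bromo weakens the compound instead of strengthening it. Before this result, no two measured compounds differed in only one place, which makes this the first direct reading of a single change on this ring: at this aromatic carbon, para to a large group, replacing hydrogen with bromo pushes the number up by more than the usual scatter. The full size of the step cannot be given because compound 3 stands at a limit of the assay, not at a measured number: the limit of > 50000 nM in this assay, at which 1 of the 3 values shown sits.

Going by these compounds, one substitution at one carbon cannot show whether this loss belongs to bromo alone or would follow from any group placed there, so the behaviour of a fluoro, a methyl or an amine at the same carbon remains open. On these data alone, it also remains open whether bromo at another carbon of this ring would raise the number in the same way.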